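Removing the chloro: from compound 3 to compound 4

The compounds below may be only part of what the source reports. "The series", "measured", "known", "first", "only" and "open" are said of these compounds alone.

Measured compounds:
- compound 1 `COc1ccc(-c2ccccc2)c2cc(C(=O)Nc3ccc(F)cc3)oc12`: "not determined" (no result reported) in a functional assay on the whole organism for inhibition, with Mus musculus as the target, at a dose of 10 mg/kg by the oral route; a higher number here means more inhibition at the dose given (going by the name of the read-out), a lower number less inhibition
- compound 2 `CNC(=O)c1cc2c(-c3ccccc3)ccc(OC)c2o1`: 18% in this assay
- compound 3 `COc1ccc(-c2ccc(Cl)cc2)c2cc(C(=O)Nc3ccncc3)oc12`: "not determined" (no result reported) in this assay

Compound 3 stands without a single number in this assay, its entry reading "not determined" (no result reported). Compound 1 is in the same position, with "not determined" (no result reported) in this assay. Within the data shown here, the only value belongs to compound 2, which gives 18% in this assay. The change from compound 3 to compound 4 `COc1ccc(-c2ccccc2)c2cc(C(=O)Nc3ccncc3)oc12` is hydrogen in place of chloro on an aromatic carbon. Among the measured compounds shown here, no step between measured compounds exists in this assay, so no direction can be read from compound 3, and a move beyond the scatter is neither expected nor ruled out. Compound 4 is expected to give about 25% in this assay, within 0% to 60%. That estimate leans only on compound 2 and its 18%.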

Compound 4, a percentage reported as inhibition, in the whole organism at one dose (the size of the read-out at that dose, not a potency): 40%
Beside the measured number, compound 4's estimate is 15 percentage points below it, and the stated range covers the measured number.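

Among these compounds, compound 4 gives the first reading for a ring on the amide-type nitrogen: in this assay, pyridin-4-yl in place of methyl gives a number 22 percentage points higher from compound 2 to compound 4 (beyond the scatter). The step from 4-chlorophenyl to phenyl itself cannot be read, and neither can any other step involving compound 1 or compound 3, as neither has a single number. No measurement at hand accounts for the rise. Still open, going by these compounds, is how a carboxylic acid or an amine on that phenyl would read, and how a longer chain on the amide-type nitrogen would compare.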